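This account rests on a few compounds, and the source may have more. Where it says the series, first, only, none or still open, it means among the compounds named here.

In a functional assay on HepG2 cells (Homo sapiens) for inhibition, read by MTT assay, with a stated time of 48 h (a higher number here means a weaker inhibitor, a lower number a stronger inhibitor), compound 2 `COc1ccc(-n2c(SCC(=O)c3ccccc3)nnc2-c2cc(OC)c(OC)c(OC)c2)cc1` gives 16200 nM. Compound 1 `COc1ccc(-n2c(SCc3ccc(C)cc3)nnc2-c2cc(OC)c(OC)c(OC)c2)cc1` gives 31600 nM, so compound 2 cannot be separated from it. Compound 3 `COc1ccc(-n2c(SCC(=O)c3ccc(OC)c(O)c3)nnc2-c2cc(OC)c(OC)c(OC)c2)cc1` reports only a limit, > 60000 nM. Compound 4 `CCOC(=O)CSc1nnc(-c2cc(OC)c(OC)c(OC)c2)n1-c1ccc(OC)cc1` departs from compound 2 by ethoxy in place of phenyl on a carbonyl carbon. Among the measured compounds shown here, no measured step makes this exact change. For the measured compounds named here, two steps bear on it: a 2.0-fold lower number from compound 1 to compound 2 (0.29 log units; within the scatter), and an at least 3.7-fold higher number from compound 2 to compound 3 (0.56 log units; beyond the scatter), the second showing that compound 3 can lose ground through a change on that carbonyl carbon. An expected 1.5-fold higher number from compound 2 to compound 4 (0.19 log units; within the scatter) therefore stays within the scatter, leaning upward. For compound 4 the estimated value is 25000 nM, with an expected range of 10000 nM to 60000 nM.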

Compound 4, half-maximal inhibitory concentration: > 60000 nM
Compound 4 gave a limit, no number (the forecaster's own chance of this, stated with the estimate: 25%); middle value at least 2.4-fold (0.38 log units) away from the limit.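

Ethoxy in place of phenyl on a carbonyl carbon gives an at least 3.7-fold higher number from compound 2 to compound 4 (0.56 log units; beyond the scatter), so the loss at this carbon is no longer confined to the 3-hydroxy-4-methoxyphenyl of compound 3: a group with no ring shows it too. Ethoxycarbonyl in place of 4-methylphenyl gives an at least 1.8-fold higher number from compound 1 to compound 4 (0.27 log units; that floor lies within the scatter), a floor that separates little. Compound 4 stands as a limit, and the step from compound 3 to compound 4 cannot be read: the limit of > 60000 nM in this assay, at which 2 of the 4 values shown sit.

Still open, from the compounds shown here alone, is whether a carboxylic acid or a methyl group on this carbonyl carbon would give a number rather than a limit.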